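A few compounds are considered here, and "the series" means these few. Any claim that something is new, unique, unknown or untested is made for them only; others in the source may bear on it.

In a functional assay on RMS13 cells for antagonist activity at Urotensin-2 receptor (Homo sapiens), read by FLIPR and calcium flux, with a stated time of 1 h (on this read-out lower numbers stand for stronger inhibition and higher numbers for weaker inhibition), compound 1 `CCN1CCN(c2cccc3c2CN([C@H](CCCNCc2cccs2)c2ccc(OC)c(OC)c2)C3=O)CC1` gives 59 nM, and compound 2 `CCN1CCN(c2cccc3c2CN([C@H](CCCNC(=O)c2cccs2)c2ccc(OC)c(OC)c2)C3=O)CC1` gives 140 nM. The step of a 2.4-fold higher number from compound 1 to compound 2 (0.38 log units; beyond the scatter) concerns a change on the chain amine, not on the piperazine. Compound 3 `COc1ccc([C@@H](CCCN(C)S(=O)(=O)c2cccs2)N2Cc3c(cccc3N3CCN(C4CCC4)CC3)C2=O)cc1OC` gives 510 nM in this assay, the highest of the three numbers, lying beyond the scatter from both compound 2 and compound 1.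

Compound 4 `COc1ccc([C@@H](CCCN(C)S(=O)(=O)c2cccs2)N2Cc3c(cccc3N3CCN(C4CC4)CC3)C2=O)cc1OC` differs from compound 3 in one place: cyclopropyl in place of cyclobutyl on an amine nitrogen in a ring. For the measured compounds named here, no measured step in this set bears on this change; compound 1 and compound 2 both carry the ethyl group on that ring nitrogen and share it, and the one step between them alters a different part of the molecule. With nothing in the data pointing either way, the swap of one small carbocycle for another on the ring nitrogen is expected to leave the number within the usual scatter, so the step of a 1.0-fold lower number from compound 3 to compound 4 (0.01 log units; within the scatter) is estimated to be essentially flat. Compound 4 is therefore expected to give about 500 nM in this assay, within a range from 200 nM to 1300 nM.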

Compound 4, half-maximal inhibitory concentration: 1200 nM
Estimate against measurement, compound 4: 2.4-fold (0.38 log units) below; low and high end bracket the measured number.
By their numbers in this assay, from the lowest: compound 1; then compound 2; then compound 3; then compound 4.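

Replacing cyclobutyl with cyclopropyl on the amine nitrogen in the ring gives a 2.4-fold higher number from compound 3 to compound 4 (0.37 log units; beyond the scatter) in this assay, so this nitrogen's substituent can move the number beyond the scatter. For the compounds shown here, the earlier compounds could not show this: compound 1 and compound 2 share the ethyl group there, and their one step lies on the chain amine. The data offer no measurement that explains the direction of this step.

As far as these compounds go, whether the number keeps rising or falling with other groups on this nitrogen, such as cyclopentyl, isopropyl or an oxetane ring, remains open. Also open, from the compounds shown here alone, is whether the same swap would produce a step of similar size in compounds carrying the (thiophen-2-yl)methyl or (thiophen-2-yl)carbonyl group on the chain amine.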